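A large side group gives way to a small silicon one

A few compounds are considered here, and "the series" means these few. Any claim that something is new, unique, unknown or untested is made for them only; others in the source may bear on it.

Of the compounds shown here, three have been tested in a functional assay on HepG2 cells (Homo sapiens) for antiproliferative activity, read by MTT assay, with a stated time of 72 h; on this read-out lower numbers stand for stronger inhibition and higher numbers for weaker inhibition. Compound 1 (`O=C1O/C(=C\Cn2cc(-c3cc(F)cc(F)c3)nn2)C(OCc2ccccc2)=C1OCc1ccccc1`) reaches only a limit of the assay, > 100000 nM. Compound 2 (`O=C1O/C(=C\Cn2cc(-c3cc(C(F)(F)F)cc(C(F)(F)F)c3)nn2)C(OCc2ccccc2)=C1OCc1ccccc1`) likewise reaches only a limit, > 100000 nM. Among the measured compounds shown here, compound 3 (`O=C1O[C@H]([C@@H](O)Cn2cc(CNS(=O)(=O)c3ccc(F)cc3)nn2)C(OCc2ccccc2)=C1OCc1ccccc1`) gives 18300 nM, the only actual number among the three. Compound 4 (`C[Si](C)(C)c1cn(C[C@H](O)[C@H]2OC(=O)C(OCc3ccccc3)=C2OCc2ccccc2)nn1`) differs from compound 3 in one place: a group of 4 heavy atoms (3 carbon, 1 silicon; no ring) in place of a group of 12 heavy atoms (7 carbon, 1 nitrogen, 2 oxygen, 1 fluorine, 1 sulfur; one six-membered aromatic ring of carbon only), on an aromatic carbon. The (((4-fluorophenyl)sulfonyl)amino)methyl group leaves, and a much smaller silicon-bearing group with no ring enters. For the measured compounds named here, no measured step shows what such a swap does, so the size of any change is uncertain. A modest weakening is expected, a 1.9-fold higher number from compound 3 to compound 4 (0.28 log units; within the scatter). For compound 4 the estimated value is 35000 nM, with an expected range of 10000 nM to 100000 nM.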

Compound 4, half-maximal inhibitory concentration: 24100 nM
Compound 4: the middle estimate sits 1.5-fold (0.16 log units) above what was measured; the measured number falls inside the stated range.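

Replacing the (((4-fluorophenyl)sulfonyl)amino)methyl group with the much smaller silicon-bearing group gives a 1.3-fold higher number from compound 3 to compound 4 (0.12 log units; within the scatter) in this assay. The two numbers cannot be told apart, so at this aromatic carbon the sulfonyl-bearing group and its aromatic ring are not needed to keep activity at this level. No step to compound 1 or compound 2 can be read: the limit of > 100000 nM in this assay, at which 2 of the 4 values shown sit.

From the compounds shown here alone, whether an amine or a carboxylic acid on this carbon would give a clearly lower number remains open. So does whether any group here can move the number beyond the scatter.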